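Swapping the Benzyl Arm on a Shared Core

The source may hold more compounds than are shown below. What is called first, only, known or untested is meant among the compounds shown, and "the series" means these compounds.

Compound 1, `NS(=O)(=O)c1ccc(CNc2nc(Nc3cccc(NC(=O)N4CCCC4)c3)ncc2Br)cc1`, gives 6170 nM in an assay on HEK293 cells for displacement of a labelled ligand from serine/threonine-protein kinase TBK1 (Homo sapiens), read by NanoBRET; a higher number here means a weaker inhibitor, a lower number a stronger inhibitor.
Compound 2, `NS(=O)(=O)c1ccc(CNc2ccnc(Nc3cccc(NC(=O)N4CCCC4)c3)n2)cc1`, gives only > 10000 nM in this assay, which is a limit of the method and not a number.

From the compounds shown here alone, compound 2 therefore stands at the edge of what this assay can report: a weak inhibitor whose true number is unknown. Among the compounds with values here, the one measured step, an at least 1.6-fold higher number from compound 1 to compound 2 (0.20 log units; that floor lies within the scatter), concerns the bromo group and is described by the limit of > 10000 nM in this assay, at which 1 of the 2 values shown sits; it says nothing about the arm that changes next. That change, (2-((cyclobutylcarbonyl)amino)ethyl in place of 4-sulfamoylphenyl on a saturated chain carbon bound to a nitrogen on an aromatic ring), gives compound 3, `O=C(NCCCNc1ccnc(Nc2cccc(NC(=O)N3CCCC3)c2)n1)C1CCC1`. Within the data shown here, no measured step bears on this replacement, so no direction can be read from the data. Compound 3 is expected near 15000 nM, in the range 4000 nM to 60000 nM. The step that the limit leaves unreadable from compound 2 to compound 3 is an estimate only, and compound 3 is expected most likely to return another limit.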

Compound 3, half-maximal inhibitory concentration: > 10000 nM
Compound 3 was reported as a limit (the forecaster's own chance of this, stated with the estimate: 70%); the middle value lies beyond the limit too.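

Compound 2 and compound 3 both rest on a limit of the method, not on a number, so no step can be read between them: the limit of > 10000 nM in this assay, at which 2 of the 3 values shown sit.

Left open is whether, in this assay, the 4-sulfamoylbenzyl or the 3-((cyclobutylcarbonyl)amino)propyl arm gives the stronger inhibitor on this shared core.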